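Piecing the Acylsulfamide Series Back Together

A few compounds are considered here, and "the series" means these few. Any claim that something is new, unique, unknown or untested is made for them only; others in the source may bear on it.

Measured compounds: compound 1 `Cc1ncsc1C(=O)NCCC1CCN(S(=O)(=O)NC(=O)NC[C@@H]2C[C@@H]3C=C[C@@H]2C3)CC1` with 25%; compound 2 `O=C(NC[C@@H]1C[C@@H]2C=C[C@@H]1C2)NS(=O)(=O)N1CCC(CCNC(=O)c2cnccc2Cl)CC1` with 12%; compound 3 `CCCNC(=O)NS(=O)(=O)N1CCC(CCNC(=O)c2cccc3c2OCCO3)CC1` with 25%.

In a functional assay on the whole organism (blood) with Rattus norvegicus as the target, with stated times of 24 h and 1 h, at a dose of 15 mg/kg by the intraperitoneal route (on this read-out higher numbers stand for a stronger effect at the one dose given and lower numbers for a weaker effect), compound 3 stands level with compound 1 at the digits shown, the two together the highest of the three numbers, while compound 2 sits lower by a number 13 percentage points lower from compound 1 to compound 2 (beyond the scatter). Compound 4 `O=C(NC[C@@H]1C[C@@H]2C=C[C@@H]1C2)NS(=O)(=O)N1CCC(CCNC(=O)c2cccc3c2OCCO3)CC1` differs from compound 3 by a group of 7 heavy atoms (7 carbon; 2 five-membered non-aromatic rings of carbon only) in place of a group of 2 heavy atoms (2 carbon; no ring), on a saturated chain carbon bound to an amide-type nitrogen, the entering group being the same one carried by compound 1 and compound 2. Among the measured compounds shown here, no measured step covers this change; the only measured step, a number 13 percentage points lower from compound 1 to compound 2 (beyond the scatter), concerns a different position. Compound 1 already pairs this group with a value matching compound 3, so little movement is expected, a number 1 percentage points lower from compound 3 to compound 4 (within the scatter). For compound 4 the estimated value is 24%, within 8% to 40%.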

Compound 4, a percentage reported as activity, at one dose (the size of the read-out at that dose, not a potency): 40%
Compound 4: middle estimate off by 16 percentage points, on the low side; measured number inside the range.
By their numbers in this assay, from the lowest: compound 2; then compounds 1 and 3 (each within the scatter of the next); then compound 4.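

In this assay, the bridged group in place of ethyl, on a saturated chain carbon bound to an amide-type nitrogen, raises the number (a number 15 percentage points higher from compound 3 to compound 4 (beyond the scatter)), so this position does respond to the change when the 2,3-dihydro-1,4-benzodioxin-5-yl amide is held fixed. With the bridged group kept, 2,3-dihydro-1,4-benzodioxin-5-yl on the carbonyl carbon also stands above both other groups (a number 15 percentage points higher from compound 1 to compound 4 (beyond the scatter); a number 28 percentage points higher from compound 2 to compound 4 (beyond the scatter)). No measurement shown explains these gains.

From the compounds shown here alone, it remains open whether a plain cyclohexyl ring at this position would give the same rise. Going by these compounds, it is also open whether the bridged group's rise depends on the 2,3-dihydro-1,4-benzodioxin-5-yl amide.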